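This account rests on a few compounds, and the source may have more. Where it says the series, first, only, none or still open, it means among the compounds named here.

Working notes on a short carbamate series tested in a functional assay on HT-29 cells (Homo sapiens) for cytotoxicity, read by MTT assay, with a stated time of 72 h; a lower number here means that less compound is tolerated, a higher number that more compound is tolerated.

Compound 1 `COc1ccc(OC(=O)Nc2ccc([Se]C#N)cc2)cc1` gives 69600 nM in this assay. Compound 2 `CC(C)COC(=O)Nc1ccc([Se][Se]c2ccc(NC(=O)OCC(C)C)cc2)cc1` gives 77400 nM. Compound 3 `CCCOC(=O)Nc1ccc([Se]C#N)cc1` gives 75400 nM. On these three numbers compound 3 stands second highest, but this rank carries no weight: its nearest neighbour is compound 2 and its furthest is compound 1, and both gaps lie within the scatter of repeated measurements, so the three compounds read as one level in this assay. Among the measured compounds shown here, no step between any two of the measured compounds is given beyond this.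

Compound 4 `CCCCOC(=O)Nc1ccc([Se]C#N)cc1` is the next member to be measured. It differs from compound 3 in one place: methyl in place of hydrogen on a saturated chain carbon, three bonds along the chain from an oxygen next to a carbonyl group. For the measured compounds named here, nothing among the measured compounds speaks to this change, since the carbamate chains of compound 1, compound 2 and compound 3 all sit at the same level in this assay.

Expectation: the step from compound 3 to compound 4 in this assay is estimated at a 1.1-fold lower number from compound 3 to compound 4 (0.03 log units; within the scatter), that is, no step beyond the scatter in either direction. Compound 4 is accordingly estimated at 70000 nM, with a range from 35000 nM to 140000 nM.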

Compound 4, concentration lethal to 50% of the cells: 63700 nM
Compound 4: middle estimate off by 1.1-fold (0.04 log units), on the high side; the range from low to high includes it.
By their numbers in this assay, from the lowest: compounds 4, 1, 3 and 2 (each within the scatter of the next).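

In this assay, among the compounds shown here, the first direct reading of this change, a 1.2-fold lower number from compound 3 to compound 4 (0.07 log units; within the scatter), comes from methyl in place of hydrogen on a saturated chain carbon, three bonds along the chain from an oxygen next to a carbonyl group, the same difference as propyl to butyl. The earlier compounds shown here offered no pair that differs in one place, whereas this pair shows that, in this one case, extending the chain at this position gives no step beyond the scatter, so propyl and butyl read as one level here. Nothing available bears on why this single change leaves the reading within the scatter.

As far as these compounds go, whether a longer chain such as hexyl at this position, or an amine or a carboxylic acid at the chain end, would give a step beyond the scatter remains open. One step at one position also leaves open how the reading responds to changes elsewhere on the shared core, and compound 1 and compound 2 cannot address this, since each differs from compound 4 in more than one place.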